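Chloroalkyl anilides of the iodoaniline core; vinyl amide proposed

This account rests on a few compounds, and the source may have more. Where it says the series, first, only, none or still open, it means among the compounds named here.

Measured so far:
compound 1, `O=C(NCCCCl)Nc1ccc(I)cc1`, in a functional assay on M21 cells (Homo sapiens) for antiproliferative activity, with a stated time of 48 h (a higher number here means a weaker inhibitor, a lower number a stronger inhibitor), gives > 100000 nM, a limit of the assay and not a number.
compound 2, `O=C(CCCl)Nc1ccc(I)cc1`, in this assay gives 20000 nM.
compound 3, `O=C(CCCCl)Nc1ccc(I)cc1`, in this assay gives > 100000 nM, again a limit of the assay.

Compound 3 therefore stands at the limit of > 100000 nM in this assay, at which 2 of the 3 values shown sit, and its value cannot be ranked against the other limit. Only compound 2 yields a number in this assay. The step from compound 2 to compound 3 is an at least 5.0-fold higher number from compound 2 to compound 3 (0.69 log units; beyond the scatter), the step from compound 1 to compound 2 is an at least 5.0-fold lower number from compound 1 to compound 2 (0.69 log units; beyond the scatter), and the step from compound 1 to compound 3 is a step that the two limits leave unreadable from compound 1 to compound 3.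

Compound 4, `C=CC(=O)Nc1ccc(I)cc1`, is not yet measured. The change from compound 3 is vinyl in place of 3-chloropropyl on a carbonyl carbon. The step that bears on it is an at least 5.0-fold higher number from compound 2 to compound 3 (0.69 log units; beyond the scatter), where a chain one carbon longer than in compound 2 moved the number to the limit; compound 4 carries a group shorter than either chain. A lower number than at compound 3 is therefore expected, in the direction of compound 2, though its size cannot be read from one step that ends at a limit. For compound 4 the expected value in this assay is 15000 nM, with a range from 3000 nM to 80000 nM. This estimate corresponds to an at least 6.6-fold lower number from compound 3 to compound 4 (0.82 log units; beyond the scatter).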

Compound 4, half-maximal inhibitory concentration: 11000 nM
Compound 4: middle estimate off by 1.4-fold (0.13 log units), on the high side; the range from low to high includes it.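

At this carbonyl carbon, a chlorine is not required for a readable number in this assay: vinyl, which carries none, gives an at least 9.0-fold lower number from compound 3 to compound 4 (0.95 log units; beyond the scatter), and set against the (3-chloropropyl)amino group it gives an at least 9.0-fold lower number from compound 1 to compound 4 (0.95 log units; beyond the scatter). Against 2-chloroethyl the same change gives a 1.8-fold lower number from compound 2 to compound 4 (0.26 log units; within the scatter), so compound 2 and compound 4 stand level in this assay, and the two groups cannot be told apart here. Compound 1 and compound 3 are limits of the assay and not numbers, and the step between them cannot be read: the limit of > 100000 nM in this assay, at which 2 of the 4 values shown sit.

What the compounds shown leave open is whether the double bond of vinyl matters at all, as a plain ethyl or a cyclopropyl group on the same carbonyl carbon would test that against chain length alone. Also open, on these data alone, is how far the numbers of compound 2 and compound 4 depend on the iodine of the shared core, which a bromine or a methoxy group in its place would address.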